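The source may hold more compounds than are shown below. What is called first, only, known or untested is meant among the compounds shown, and "the series" means these compounds.

Measured so far in a functional assay on the whole organism with Mus musculus as the target, in the rotarod test; a lower number here means that less compound is needed, a higher number that more compound is needed for the effect:

compound 1 `CCNC(=O)/C=C1\CCc2ccc(F)cc21` gives 136 mg/kg
compound 2 `O=C(/C=C1\CCc2c(F)cc(F)cc21)NC1CC1` gives 62 mg/kg
compound 3 `NC(=O)/C=C1\CCc2ccc(F)cc21` gives 90 mg/kg

Compound 3 is the starting point here. Its number lies within the usual scatter of both compound 1 and compound 2, so these data give it no clear rank among the three.

The next compound is compound 4 `O=C(/C=C1\CCc2ccc(F)cc21)NC1CC1`, which differs from compound 3 in one place: cyclopropyl in place of hydrogen on an amide-type nitrogen.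

For the measured compounds named here, only one measured step changes that nitrogen with the rest of the structure held constant: a 1.5-fold lower number from compound 1 to compound 3 (0.18 log units; within the scatter), where hydrogen replaces ethyl. This is a single pair, and ethyl is not cyclopropyl, so it is only a rough guide. Going by the values given here, compound 2 also carries cyclopropyl on that nitrogen, but its core is not the same as that of compound 3, so no measured step isolates the cyclopropyl group.

Given the small size of a 1.5-fold lower number from compound 1 to compound 3 (0.18 log units; within the scatter), no shift beyond the scatter is expected in either direction. Among the compounds with values here, the expected change is a 1.1-fold lower number from compound 3 to compound 4 (0.02 log units; within the scatter), which is no real step at all. For compound 4 the estimated value is 85 mg/kg in this assay, with an expected range from 42 mg/kg to 170 mg/kg as the outcome.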

Compound 4, dose for half-maximal effect: 62 mg/kg
Compound 4: middle estimate off by 1.4-fold (0.14 log units), on the high side, within the range that was stated.
By their numbers in this assay, from the lowest: compounds 2, 4, 3 and 1 (each within the scatter of the next, the first and the last beyond it).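

In this assay, cyclopropyl in place of hydrogen on the amide-type nitrogen does not separate the two compounds beyond the scatter (a 1.5-fold lower number from compound 3 to compound 4 (0.16 log units; within the scatter)), so this nitrogen can carry this three-membered ring with the dose staying in the same range. Cyclopropyl in place of ethyl at that same place is the first single change at this nitrogen to pass the scatter (a 2.2-fold lower number from compound 1 to compound 4 (0.34 log units; beyond the scatter)), though only modestly, which shows that the choice of group here can count, even though compound 3, with only hydrogen on the nitrogen, lies within the scatter of both compound 1 and compound 4. For the compounds shown here, the new compound also gives the first direct reading of the extra fluoro on an aromatic carbon: with hydrogen in its place, the pair shows nothing (no change at the digits printed from compound 2 to compound 4 (within the scatter)), so in this one pair that fluoro makes no visible difference.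

Nothing measured here gives a reason for these numbers. Still open, from the compounds shown here alone, is whether a longer chain or a phenyl ring on the nitrogen would move the number beyond the scatter of compound 4, and whether chloro on that aromatic carbon would read the same as fluoro and hydrogen do.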